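Series notes: carbonyl substituent change from compound 3 to compound 4

The source may hold more compounds than are shown below. What is called first, only, known or untested is meant among the compounds shown, and "the series" means these compounds.

Compound 1 `O=C(Nc1ccc(S(=O)(=O)N2CCOCC2)c2ccccc12)c1ccccc1` gives 7750 nM in an assay on L1.2 cells for binding affinity to C-C chemokine receptor type 8 (Homo sapiens); on this read-out higher numbers stand for weaker inhibition and lower numbers for stronger inhibition. Compound 2 `CCOC(=O)N1CCC(NS(=O)(=O)c2ccc(OC(=O)c3ccccc3)c3ccccc23)CC1` gives 16.4 nM in this assay, and compound 3 `Cc1ccccc1C(=O)Nc1ccc(S(=O)(=O)NC2CCN(C(=O)C3CCCC3)CC2)c2ccccc12` gives 9.1 nM. Compound 3 thus holds the lowest number of the three measured; compound 2 sits within the scatter of it, while compound 1 lies far beyond.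

Compound 4 `CCCNC(=O)N1CCC(NS(=O)(=O)c2ccc(NC(=O)c3ccccc3C)c3ccccc23)CC1` differs from compound 3 by propylamino in place of cyclopentyl on a carbonyl carbon. No step between measured compounds touches this part of the molecule, so the direction is unsupported by any shown pair. The change is expected to be small, with the step of a 1.3-fold higher number from compound 3 to compound 4 (0.12 log units; within the scatter) estimated to stay within the scatter. Compound 4 is estimated at 12 nM, with a range from 4 nM to 40 nM.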

Compound 4, inhibition constant: 77.4 nM
Compound 4: the middle estimate sits 6.5-fold (0.81 log units) below what was measured; the measured number lies above the stated range.
By their numbers in this assay, from the lowest: compounds 3 and 2 (each within the scatter of the next); then compound 4; then compound 1.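

Going by these compounds alone, this is the first step at the group on the carbonyl carbon whose other neighbour is an amide-type nitrogen in a ring. In this assay, within the data shown here, propylamino in place of cyclopentyl gives an 8.5-fold higher number from compound 3 to compound 4 (0.93 log units; beyond the scatter) and shows that this position responds to the change, yet the single step loses the carbon-only ring and gains a nitrogen with its hydrogen-bond donor together, so the two differences stay unseparated. No evidence on hand explains the rise.

Open, on these data alone, is whether cyclopentylamino, which keeps the ring and adds the nitrogen, or butyl, an open chain without nitrogen, would stay nearer compound 3 or compound 4.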